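Thiazolyl for fluorophenyl on the cyclopropane of compound 3

This account rests on a few compounds, and the source may have more. Where it says the series, first, only, none or still open, it means among the compounds named here.

Measured so far:
compound 1 `CC(C)[C@H](N)CN(C(=O)[C@@H]1C[C@H]1c1ccccc1)c1ccc(-c2ccccc2)cc1`, 1.1 nM
compound 2 `O=C([C@@H]1C[C@H]1c1ccccc1)N(CC1CCCNC1)c1ccc(-c2ccccc2)cc1`, 10 nM
compound 3 `CC[C@H](C)[C@H](N)CN(C(=O)[C@@H]1C[C@H]1c1ccccc1F)c1ccc(-c2ccccc2)cc1`, 650 nM

In a functional assay for agonist activity at G protein-coupled receptor 88 (Homo sapiens), read by HTRF and cAMP accumulation (a higher number here means that more compound is needed for the effect, a lower number that less compound is needed), compound 3 stands with the highest number of the three; compound 2 is nearest and compound 1 furthest, both well beyond the scatter. Compound 4 `CC[C@H](C)[C@H](N)CN(C(=O)[C@@H]1C[C@H]1c1nccs1)c1ccc(-c2ccccc2)cc1` differs from compound 3 in one place: 1,3-thiazol-2-yl in place of 2-fluorophenyl on a saturated ring carbon. Among the measured compounds shown here, the only measured step, a 9.1-fold higher number from compound 1 to compound 2 (0.96 log units; beyond the scatter), concerns the chain on the amide-type nitrogen and says nothing about the group on the cyclopropane. For the measured compounds named here, no measured step therefore bears on the change from compound 3 to compound 4, and no direction can be expected beyond the scatter. Compound 4 is estimated at 650 nM (range 130 nM to 3300 nM), a step of no change at the digits printed from compound 3 to compound 4 (within the scatter), with a wide range.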

Compound 4, half-maximal effective concentration: 210 nM
For compound 4 the middle estimate is 3.1-fold (0.49 log units) above the measured one, and the stated range covers the measured number.
By their numbers in this assay, from the lowest: compound 1; then compound 2; then compound 4; then compound 3.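

On the saturated ring carbon of the cyclopropane, the aromatic group can change and the number still moves: in this assay, 1,3-thiazol-2-yl in place of 2-fluorophenyl gives a 3.1-fold lower number from compound 3 to compound 4 (0.49 log units; beyond the scatter). A five-membered aromatic ring with 2 hetero atoms is therefore tolerated here, and a six-membered aromatic ring of carbon only is not required for activity in this pair. Nothing available accounts for the size of this step.

Open, from the compounds shown here alone, is whether a pyridin-2-yl group at this place would give a similar number. Also open, going by these compounds, is whether the step carries over to compounds with the 1-amino-2-methylpropyl chain of compound 1.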